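The source may hold more compounds than are shown below. What is called first, only, known or untested is meant among the compounds shown, and "the series" means these compounds.

Measured compounds:
Compound 1, `Cc1c(-c2cc(Cl)cc(Cl)c2)c(C(=O)O)nn1-c1nc(-c2cc(Cl)ccc2F)c(SC(C)C)s1`: in a functional assay on BJAB cells (Homo sapiens) for antiproliferative activity, with a stated time of 4 days (a lower number here means that less compound is needed, a higher number that more compound is needed for the effect), compound 1 gives 4800 nM.
Compound 2, `Cc1c(-c2cc(Cl)cc(Cl)c2)c(C(=O)O)nn1-c1nc(-c2cnn(C)c2)c(SC(C)C)s1`: in this assay compound 2 gives "not active" (no number reported).
Compound 3, `Cc1cc(C)cc(-c2c(C)nn(-c3nc(-c4ccc(Cl)c(Cl)c4)c(SC(C)C)s3)c2C(=O)O)c1`: in this assay compound 3 gives 2700 nM.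

Only two of the three measured compounds give a number. Of these, compound 3 has the lower one, but the gap to compound 1 lies within the usual scatter of this assay, so the two cannot be told apart on these numbers; compound 2 gives no number at all. All three share the same core, and they differ in the groups attached to it.

Compound 4, `CNc1cc(-c2c(C)nn(-c3nc(-c4ccc(Cl)c(Cl)c4)c(SC(C)C)s3)c2C(=O)O)ccn1`, has not yet been measured. It differs from compound 3 in a single place: 2-(methylamino)pyridin-4-yl in place of 3,5-dimethylphenyl on an aromatic carbon. Among the compounds with values here, no pair among the measured compounds shows a change of this kind, so there is no measured step to rest an expectation on, and the estimate has to stay close to compound 3 with wide uncertainty. The step of a 1.5-fold higher number from compound 3 to compound 4 (0.17 log units; within the scatter) is expected to be small, if anything toward a higher number, and may well fall within the scatter. Compound 4 is expected to give about 4000 nM in this assay, with a range from 1000 nM to 20000 nM.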

Compound 4, half-maximal effective concentration: 18000 nM
The estimate for compound 4 lay 4.5-fold (0.65 log units) below the measured number; measured number inside the range.
By their numbers in this assay, from the lowest: compounds 3 and 1 (each within the scatter of the next); then compound 4.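

Swapping 3,5-dimethylphenyl for 2-(methylamino)pyridin-4-yl on this aromatic carbon gives a 6.7-fold higher number from compound 3 to compound 4 (0.82 log units; beyond the scatter) in this assay, so the number responds clearly to what sits at this position of the shared core. The two groups match in heavy-atom count and each is a six-membered aromatic ring, which shows that a swap of equal size can still produce a step beyond the scatter; what differs is that the entering group has a ring nitrogen and brings a hydrogen-bond donor and acceptors, which the leaving group lacks. Nothing measured here accounts for this step.

The compounds shown do not separate the ring nitrogen from the methylamino group, so a plain pyridin-4-yl group or a phenyl ring carrying only a methylamino group would be needed to tell which of the two goes with the higher number. They also leave open whether a 2-aminopyridin-4-yl group, without the methyl, or a 2-methoxypyridin-4-yl group, with oxygen in place of the amine nitrogen, would behave the same way at this position.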